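The source may report more compounds than this note shows. Statements on the series, on what has been measured and on what is new or still open speak of the compounds shown alone.

Compounds measured in an assay on CHO cells for binding affinity to Melanocortin receptor 4 (Homo sapiens); a higher number here means a weaker inhibitor, a lower number a stronger inhibitor:
compound 1 `COc1ccc(-n2nc(Sc3ccc(Cl)cc3)cc(CC[C@@H](C)NC(=O)[C@H]3CCNC[C@@H]3c3ccc(Cl)cc3)c2=O)cc1`, 58 nM
compound 2 `COc1ccc(-n2nc(Sc3ccc(Cl)cc3)cc(CC[C@@H](C)NC(=O)[C@H]3CCNC[C@@H]3c3ccc(F)cc3)c2=O)cc1`, 66 nM
compound 3 `COc1ccc(-n2nc(Sc3ccc(Cl)cc3)cc(CC[C@@H](C)NC(=O)[C@H]3CNC[C@@H]3c3ccccc3F)c2=O)cc1`, 160 nM

Compound 3 gives the highest number of the three; its gap to compound 2 and its gap to compound 1 both lie beyond the scatter. Compound 4 `COc1ccc(-n2nc(Sc3ccc(Cl)cc3)cc(CC[C@@H](C)NC(=O)[C@H]3CNC[C@@H]3c3ccc(F)cc3F)c2=O)cc1` differs from compound 3 by fluoro in place of hydrogen on an aromatic carbon, meta to a fluoro group and para to a large group, turning 2-fluorophenyl into 2,4-difluorophenyl. For the measured compounds named here, the only measured step touching a halogen on that ring, a 1.1-fold higher number from compound 1 to compound 2 (0.06 log units; within the scatter), lies within the scatter, and it concerns a different core, so it bears only weakly here. Going by the values given here, no step beyond the scatter is expected; the expected step is a 1.2-fold lower number from compound 3 to compound 4 (0.09 log units; within the scatter). Compound 4 is estimated at 130 nM in this assay, within a range from 60 nM to 350 nM.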

Compound 4, half-maximal inhibitory concentration: 60 nM
The estimate for compound 4 lay 2.2-fold (0.34 log units) above the measured number; measured number inside the range.
By their numbers in this assay, from the lowest: compounds 1, 4 and 2 (each within the scatter of the next); then compound 3.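

In this assay, going from 2-fluorophenyl to 2,4-difluorophenyl gives a 2.7-fold lower number from compound 3 to compound 4 (0.43 log units; beyond the scatter), so a fluoro on this aromatic carbon, meta to a fluoro group and para to a large group, moves the number beyond the scatter. The earlier halogen step, a 1.1-fold higher number from compound 1 to compound 2 (0.06 log units; within the scatter), stayed within the scatter, but it swapped one halogen for another on a different core. No measurement available here explains the change. The compounds shown leave open whether a chloro or methoxy group on this same carbon would give a similar number, and whether adding this fluoro to the core of compound 2 would do the same.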